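Hydroxymethylphenyl in place of carbamoylphenyl on the biaryl arm

This account rests on a few compounds, and the source may have more. Where it says the series, first, only, none or still open, it means among the compounds named here.

Two compounds of this series carry numbers in a functional assay on blood for antagonist activity at thromboxane A2 receptor (Homo sapiens); on this read-out lower numbers stand for tighter binding and higher numbers for weaker binding. Compound 1 `O=C(O)CC/C=C\CO[C@H]1C(OCc2ccc(-c3ccccc3CCO)cc2)CC[C@@H]1N1CCCCCC1` gives 2 nM. Compound 2 `NC(=O)c1ccccc1-c1ccc(COC2CC[C@H](N3CCCCCC3)[C@H]2OC/C=C\CCC(=O)O)cc1` gives 15.9 nM, the highest of the two numbers, the other belonging to compound 1. Going by the values given here, the single measured step, an 8.0-fold higher number from compound 1 to compound 2 (0.90 log units; beyond the scatter), puts a carbamoyl where compound 1 bears a 2-hydroxyethyl.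

Compound 3 `O=C(O)CC/C=C\CO[C@H]1C(OCc2ccc(-c3ccc(CO)cc3)cc2)CC[C@@H]1N1CCCCCC1` has not been measured in this assay. It differs from compound 2 at one site: 4-(hydroxymethyl)phenyl in place of 2-carbamoylphenyl on an aromatic carbon. The change brings back a hydroxyl-bearing substituent, as in compound 1, but at a different position on the ring, so the step from compound 1 to compound 2 bears on it only loosely. Compound 3 is therefore expected to land between the two measured numbers, closer to compound 1, with a step of a 3.2-fold lower number from compound 2 to compound 3 (0.50 log units; beyond the scatter) toward a lower number. Compound 3 is estimated at 5 nM, within a range of 1.5 nM to 20 nM.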

Compound 3, dissociation constant: 3.16 nM
Estimate against measurement, compound 3: 1.6-fold (0.20 log units) above; low and high end bracket the measured number.
By their numbers in this assay, from the lowest: compounds 1 and 3 (each within the scatter of the next); then compound 2.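

Placing 4-(hydroxymethyl)phenyl where compound 2 carries 2-carbamoylphenyl gives a 5.0-fold lower number from compound 2 to compound 3 (0.70 log units; beyond the scatter) in this assay and thus shows that this aromatic carbon tolerates a hydroxyl-bearing group other than the 2-(2-hydroxyethyl)phenyl of compound 1. The other step, a 1.6-fold higher number from compound 1 to compound 3 (0.20 log units; within the scatter) between these two hydroxyl-bearing groups, shows that this read-out does not tell them apart, although their names place the substituents differently on the ring. Nothing measured here accounts for the difference from the carbamoyl compound.

The compounds shown do not separate the effect of the carbamoyl group from that of its place on the ring, a question that 4-carbamoylphenyl would address. On these data alone, how an aminomethyl group or a carboxylic acid would behave on the same ring also remains open.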